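The source may report more compounds than this note shows. Statements on the series, on what has been measured and on what is new or still open speak of the compounds shown alone.

Among the compounds with values here, in an assay on isolated protein (strain Sprague-Dawley) for inhibition of Amine oxidase [flavin-containing] A (Rattus norvegicus), read by spectrophotometry, with a stated time of 5 min, tested at 10 uM (a lower number here means less inhibition, a higher number more inhibition at the concentration tested (going by the name of the read-out)), compound 1 `O=c1cc(O)c2ccc(OCc3cccc(Br)c3)cc2o1` gives 0%, while compound 2 `COc1cc(=O)oc2cc(OCc3cccc(Br)c3)ccc12` gives 27%; the step of a number 27 percentage points higher from compound 1 to compound 2 (beyond the scatter) is the only measured change in one place. Compound 3 `CN(C)C(=O)COc1cc(=O)oc2cc(OCc3cccc(Cl)c3)ccc12` gives 10% in this assay, standing second highest of the three numbers, within the scatter of compound 1 and beyond the scatter below compound 2. Compound 4 `N#Cc1cc(=O)oc2cc(OCc3cccc(Cl)c3)ccc12` differs from compound 3 by cyano in place of (dimethylcarbamoyl)methoxy on an aromatic carbon. Within the data shown here, no measured step exchanges a group at this position; the one measured step, methyl in place of hydrogen on an oxygen on an aromatic ring, alters a different group and does not bear directly on this change. Among the measured compounds shown here, with no guiding step, compound 4 is expected to stay near compound 3, an expected step of a number 2 percentage points higher from compound 3 to compound 4 (within the scatter). The estimate for compound 4 is 12%, between 0% and 30%.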

Compound 4, a percentage reported as inhibition, at one concentration (the size of the read-out at that concentration, not a potency): 23%
Compound 4: the middle estimate sits 11 percentage points below what was measured; the measured number falls inside the stated range.
By their numbers in this assay, from the lowest: compounds 1 and 3 (each within the scatter of the next); then compounds 4 and 2 (each within the scatter of the next).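

In this assay, cyano in place of (dimethylcarbamoyl)methoxy on the aromatic carbon opposite the ring oxygen gives a number 13 percentage points higher from compound 3 to compound 4 (beyond the scatter), the first exchange shown at this position. The group on this carbon can therefore move the inhibition read at the tested concentration, and here the entering group has 2 heavy atoms against 7 for the one leaving. Nothing given here accounts for the rise.

As far as these compounds go, whether the change comes from gaining cyano or from losing the longer group remains open. So does what an amine or a carboxylic acid on this carbon would give.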